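Cycloheptyl to Cyclooctyl in Compound 1

A few compounds are considered here, and "the series" means these few. Any claim that something is new, unique, unknown or untested is made for them only; others in the source may bear on it.

Two compounds sharing the same core have numbers in a functional assay on MIA PaCa-2 cells (Homo sapiens) for cytotoxicity, read by fluorescence, with a stated time of 48 h; a lower number here means that less compound is needed, a higher number that more compound is needed for the effect. Compound 1 `CC(C)=CCC/C(C)=C/CC/C(C)=C/CSC[C@H](NC(=O)CCCCCN1CCN(C)CC1)C(=O)NC1CCCCCC1` gives 2700 nM, and compound 2 `CC(C)=CCC/C(C)=C/CC/C(C)=C/CSC[C@H](NC(=O)CCCCCN1CCCC1)C(=O)NC1CCCCC1` gives 5600 nM. Compound 1 therefore holds the lower of the two numbers, and the gap between them lies beyond the usual scatter. The two compounds differ in more than one place, so this gap cannot be assigned to any single group.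

Compound 3 `CC(C)=CCC/C(C)=C/CC/C(C)=C/CSC[C@H](NC(=O)CCCCCN1CCN(C)CC1)C(=O)NC1CCCCCCC1` has not yet been measured. It departs from compound 1 in one place, with cyclooctyl in place of cycloheptyl on an amide-type nitrogen. Among the compounds with values here, no measured pair shows this change on its own, so the expectation rests mainly on compound 1 and its 2700 nM. In this assay, no step beyond the scatter is expected in either direction. The estimated step of a 1.1-fold lower number from compound 1 to compound 3 (0.03 log units; within the scatter) is a small one and carries little confidence in its direction. Compound 3 is expected to give 2500 nM, with an estimated range of 1200 nM to 5200 nM.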

Compound 3, half-maximal effective concentration: 2500 nM
The estimate for compound 3 equals the measured number at the digits printed; the range from low to high includes it.
By their numbers in this assay, from the lowest: compounds 3 and 1 (each within the scatter of the next); then compound 2.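

In this assay, cyclooctyl in place of cycloheptyl on an amide-type nitrogen gives a 1.1-fold lower number from compound 1 to compound 3 (0.03 log units; within the scatter), and this is the only comparison among the compounds shown that isolates one place. Compound 1 and compound 2 differ in more than one place, so their gap could not speak to this position alone, whereas this pair shows that the two carbon-only rings cannot be told apart here beyond the scatter. Nothing measured here offers an explanation for this result, so no cause can be assigned to it.

Within the data shown here, the pair covers only two large carbon-only rings at this position, so it remains open how the number would respond to an open-chain group such as tert-butyl, or to a ring or chain carrying a carboxylic acid or an amine. A single pair also cannot show whether cycloheptyl and cyclooctyl would still read alike if other parts of the shared core were changed, for example if a longer chain replaced the one that carries the terminal amine.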